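Swapping ethyl for chloro on compound 3

This account rests on a few compounds, and the source may have more. Where it says the series, first, only, none or still open, it means among the compounds named here.

Going by the values given here, in a functional assay on A549 cells (Homo sapiens) for cytotoxicity, read by MTT assay, with a stated time of 72 h (a higher number here means a weaker inhibitor, a lower number a stronger inhibitor), compound 3 `CCc1ccc(-c2cc(C(=O)Nc3ccc(Oc4ccnc(C(=O)NC)c4)cc3)ncn2)cc1` gives 13300 nM as the only true number so far. Compound 1 `CNC(=O)c1cc(Oc2ccc(NC(=O)c3cc(-c4ccc(Cl)cc4)ncn3)cc2F)ccn1` shows > 100000 nM as a limit of the assay and not a number. Compound 2 `CNC(=O)c1cc(Oc2ccc(NC(=O)c3cc(-c4ccc(Br)cc4)ncn3)cc2)ccn1` likewise shows > 100000 nM as a limit. Among the compounds with values here, compound 4 `CNC(=O)c1cc(Oc2ccc(NC(=O)c3cc(-c4ccc(Cl)cc4)ncn3)cc2)ccn1` is still unmeasured and carries chloro in place of ethyl on an aromatic carbon as its only change from compound 3. Within the data shown here, the one measured step bearing on this is an at least 7.5-fold lower number from compound 2 to compound 3 (0.87 log units; beyond the scatter) with ethyl in place of bromo, which lies beyond the scatter, so a swap from ethyl to chloro should raise the number. The expected step is a 4.1-fold higher number from compound 3 to compound 4 (0.62 log units; beyond the scatter) towards weaker inhibition, and the reading may well reach the limit of the assay. For compound 4 the estimated value is 55000 nM with an expected range of 22000 nM to 100000 nM overall.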

Compound 4, half-maximal inhibitory concentration: > 100000 nM
Compound 4: no number, only a limit; the forecaster's own chance of this, stated with the estimate: 55%; middle value at least 1.8-fold (0.25 log units) from the limit.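

Putting chloro in place of ethyl gives an at least 7.5-fold higher number from compound 3 to compound 4 (0.87 log units; beyond the scatter) in this assay, so chloro, like bromo in compound 2, loses the true reading that ethyl gives at this position. The steps from compound 1 and compound 2 to compound 4 cannot be read, as both ends of each are limits. Ethyl therefore remains the only group here with a true number, and the rest sit at one limit: the limit of > 100000 nM in this assay, at which 3 of the 4 values shown sit.

On these data alone, how far compound 4 lies past that limit stays open. So does whether a methoxy group, an amine or a longer alkyl chain at this position would give a true number.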